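From nitro to bromo on the shared core

The source may hold more compounds than are shown below. What is called first, only, known or untested is meant among the compounds shown, and "the series" means these compounds.

In a functional assay on HGC cells (Homo sapiens) for cytotoxicity, read by MTT assay, with a stated time of 48 h (on this read-out lower numbers stand for stronger inhibition and higher numbers for weaker inhibition), compound 1 (`CCn1c(/C=C2/C(=O)Nc3ccccc32)nc2ccccc21`) gives > 50000 nM as a limit of the assay and not a number. Compound 2 (`Cn1c(/C=C2/C(=O)Nc3ccc([N+](=O)[O-])cc32)nc2ccccc21`) has no number there, its entry reading "not determined" (no result reported) in the report. The sole reference on the scale is the limit of > 50000 nM in this assay, at which 1 of the 2 values shown sits, for now. Compound 3 (`Cn1c(/C=C2/C(=O)Nc3ccc(Br)cc32)nc2ccccc21`) is the next structure. The change bromo in place of nitro on an aromatic carbon puts bromo in place of nitro on an aromatic carbon. Within the data shown here, no measured step gauges this change, so no large shift in either direction is expected in this assay and weak inhibition is expected. For compound 3 the estimated value is 30000 nM with an expected range from 8000 nM to 100000 nM in this read-out.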

Compound 3, half-maximal inhibitory concentration: > 50000 nM
Compound 3: only a limit was reported; the forecaster's own chance of this, stated with the estimate: 45%; middle value at least 1.6-fold (0.22 log units) away from the limit.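

No step can be read between compound 2 and compound 3. Compound 3 gives > 50000 nM in this assay, which is a limit of the assay. The compounds shown leave open whether swapping nitro for bromo on the shared core changes cytotoxicity at all.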